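Aryl amide swap on the shared core: compound 1 to compound 4

The compounds below may be only part of what the source reports. "The series", "measured", "known", "first", "only" and "open" are said of these compounds alone.

Compound 1 `O=C(Nc1ccc2nc(NC(=O)C3CCCCC3)sc2c1)c1ccccc1Cl` gives 0.025 ug/mL in a functional assay on WI-38 VA13 cells (Homo sapiens) for cytotoxicity (on this read-out lower numbers stand for an effect already at smaller amounts and higher numbers for an effect only at larger amounts of compound), the second highest of three numbers. Compound 3 `Cc1[nH][n+](C)c(C)c1C(=O)Nc1ccc2nc(NC(=O)C3CCCCC3)sc2c1` gives 0.012 ug/mL in this assay; compound 2 `COc1ccc(C(=O)Nc2ccc3nc(NC(=O)C4CCCCC4)sc3c2)cc1` gives 4.9 ug/mL. Compound 4 `Cc1coc(C)c1C(=O)Nc1ccc2nc(NC(=O)C3CCCCC3)sc2c1` is not yet measured; relative to compound 1 the change is 2,4-dimethylfuran-3-yl in place of 2-chlorophenyl on a carbonyl carbon. Two measured steps alter the same group on the carbonyl carbon: a 200-fold higher number from compound 1 to compound 2 (2.29 log units; beyond the scatter), a large loss, and a 2.1-fold lower number from compound 1 to compound 3 (0.32 log units; beyond the scatter), a modest gain. Among the compounds with values here, the group on this carbonyl thus spans a wide range, and a five-membered aromatic ring with one hetero atom has no direct precedent here. The expectation for compound 4 is a small loss, a 4.8-fold higher number from compound 1 to compound 4 (0.68 log units; beyond the scatter), with wide uncertainty. Compound 4 is estimated at 0.12 ug/mL, between 0.012 ug/mL and 1.5 ug/mL.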

Compound 4, half-maximal effective concentration: 2.7 ug/mL
Compound 4: middle estimate off by 23-fold (1.35 log units), on the low side; the measured number lies above the stated range.
By their numbers in this assay, from the lowest: compound 3; then compound 1; then compounds 4 and 2 (each within the scatter of the next).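

In this assay, a five-membered aromatic ring on this carbonyl carbon does not by itself keep the number low: a 230-fold higher number from compound 3 to compound 4 (2.35 log units; beyond the scatter), and a 110-fold higher number from compound 1 to compound 4 (2.03 log units; beyond the scatter). The 2,4-dimethylfuran-3-yl group instead sits with 4-methoxyphenyl, a 1.8-fold lower number from compound 2 to compound 4 (0.26 log units; within the scatter), so very different aromatic groups can share the high end of the range. No available evidence accounts for this split. Still open, as far as these compounds go, is whether a pyridine ring or a butyl chain in place of 2-chlorophenyl would fall with compounds 1 and 3 or with compounds 2 and 4.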